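Side-chain amine change on the shared core

A few compounds are considered here, and "the series" means these few. Any claim that something is new, unique, unknown or untested is made for them only; others in the source may bear on it.

In a functional assay on SH-SY5Y cells (Homo sapiens) for cytotoxicity, read by MTT assay, with a stated time of 72 h (a higher number here means a weaker inhibitor, a lower number a stronger inhibitor), compound 2 `CN(C)CCCCn1c2c(c3ccccc31)C(=O)c1c[n+]([O-])c3ccccc3c1C2=O` gives 250 nM and compound 1 `CN(C)CCCCCn1c2c(c3ccccc31)C(=O)c1c[n+]([O-])c3ccccc3c1C2=O` gives 370 nM, so the two lie within the scatter of each other. The change to compound 3 `CN1CCN(CCCCCn2c3c(c4ccccc42)C(=O)c2c[n+]([O-])c4ccccc4c2C3=O)CC1` is (4-methylpiperazin-1-yl)methyl in place of dimethylamino on a saturated chain carbon, four bonds along the chain from an aromatic nitrogen. Among the measured compounds shown here, the only measured step bearing on it is a 1.5-fold lower number from compound 1 to compound 2 (0.17 log units; within the scatter), a smaller change on the same chain. For the measured compounds named here, no measured compound carries (4-methylpiperazin-1-yl)methyl, so no direction can be argued, and no shift beyond the scatter is expected in this assay. The expected step is a 1.2-fold higher number from compound 2 to compound 3 (0.08 log units; within the scatter). Compound 3 is estimated at 300 nM, with a range of 100 nM to 900 nM.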

Compound 3, half-maximal inhibitory concentration: 830 nM
The estimate for compound 3 lay 2.8-fold (0.44 log units) below the measured number, and the stated range covers the measured number.
By their numbers in this assay, from the lowest: compounds 2 and 1 (each within the scatter of the next); then compound 3.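

In this assay the 4-methylpiperazin-1-yl group at the chain end is the only change shown on this side chain that goes beyond the scatter, with a 3.3-fold higher number from compound 2 to compound 3 (0.52 log units; beyond the scatter) and, at unchanged chain length, a 2.2-fold higher number from compound 1 to compound 3 (0.35 log units; beyond the scatter) in the same direction. Before this, a 1.5-fold lower number from compound 1 to compound 2 (0.17 log units; within the scatter) gave no sign that this side chain could move the number at all.

Still open, from the compounds shown here alone, is whether a morpholine or a primary amine at the chain end would behave like the 4-methylpiperazin-1-yl group, and what that group does on the shorter chain of compound 2. No measured evidence accounts for the shift.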